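The source may hold more compounds than are shown below. What is called first, only, known or untested is meant among the compounds shown, and "the series" means these compounds.

Measured compounds in a functional assay on NCI-H1299 cells (Homo sapiens) for inhibition, read by scintillation counting, with a stated time of 30 min, tested at 30 uM; on this read-out higher numbers stand for more inhibition at the one concentration tested (going by the name of the read-out) and lower numbers for less inhibition:
- compound 1 `COc1cccc(OC(=O)c2cc(O)cc(O)c2)c1OC(=O)c1cc(O)cc(O)c1`: 69.4%
- compound 2 `O=C(Oc1cccc(F)c1OC(=O)c1cc(O)cc(O)c1)c1cc(O)cc(O)c1`: 94%

Compound 2 stands highest of the two numbers shown; its nearest neighbour is compound 1, reached by the step of a number 24.6 percentage points higher from compound 1 to compound 2 (beyond the scatter), which lies beyond the scatter. Compound 3 `O=C(Oc1cccc(OC(=O)c2cc(O)cc(O)c2)c1OC(=O)c1cc(O)cc(O)c1)c1cc(O)cc(O)c1` differs from compound 2 in one place: ((3,5-dihydroxyphenyl)carbonyl)oxy in place of fluoro on an aromatic carbon.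

Going by the values given here, only one measured step bears on this change, and only loosely. The step from compound 1 to compound 2 swapped methoxy for fluoro at the same aromatic carbon and gave a modest rise. Among the compounds with values here, the change to compound 3 removes that fluoro and puts in an oxygen-linked ((3,5-dihydroxyphenyl)carbonyl)oxy group, so the single methoxy-bearing analogue, compound 1, is the closest guide, and it sat below compound 2. Within the data shown here, no step for a group of this size at this position has been measured, so this guide rests on a single step only.

Compound 3 is therefore expected to give a somewhat lower number than compound 2, with the step of a number 14 percentage points lower from compound 2 to compound 3 (beyond the scatter) estimated to be modest and near the edge of the scatter. The estimate for compound 3 is 80%, within a range from 55% to 97%.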

Compound 3, a percentage reported as inhibition, at one concentration (the size of the read-out at that concentration, not a potency): 98.7%
Compound 3: middle estimate off by 18.7 percentage points, on the low side, outside the stated range (above it).
By their numbers in this assay, from the lowest: compound 1; then compounds 2 and 3 (each within the scatter of the next).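

In this assay, the step from fluoro to ((3,5-dihydroxyphenyl)carbonyl)oxy is a number 4.7 percentage points higher from compound 2 to compound 3 (within the scatter), so this position on the aromatic carbon accepts a group of 11 heavy atoms, with an added aromatic ring, and inhibition stays level with that of the single fluorine. Set against the methoxy analogue, the change of methyl to (3,5-dihydroxyphenyl)carbonyl on the same oxygen is a number 29.3 percentage points higher from compound 1 to compound 3 (beyond the scatter), which leaves compound 1 as the only one of the three that stands apart, while compound 2 and compound 3 cannot be ranked against each other. The data offer no measured explanation for why the methoxy analogue stands apart or why so different a pair of groups reads alike.

Both of the upper numbers lie close to the top of a percentage scale at one concentration, so the compounds shown leave open whether fluoro and the larger ester would still read alike under conditions that could separate them. They also leave open how an amine, a carboxylic acid or a longer alkyl chain would read on this aromatic carbon.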